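The compounds below may be only part of what the source reports. "The series", "measured", "known", "first", "only" and "open" are said of these compounds alone.

Measured compounds:
Compound 1 `CC(C)(C)c1nc(NC#N)ncc1-c1ccccc1` gives < 5% in a functional assay on the whole organism for inhibition, with Rattus norvegicus as the target, with stated times of 1 h and 3.5 h, at a dose of 100 mg/kg by the oral route (a higher number here means more inhibition at the dose given (going by the name of the read-out), a lower number less inhibition), a limit of the assay rather than a number.
Compound 2 `CC(=O)N(C(C)=O)c1ncc(-c2ccccc2)c(C(C)(C)C)n1` gives 22% in this assay.
Compound 3 `CNc1ncc(-c2ccccc2)c(C(C)(C)C)n1` gives 37% in this assay.

Of the two numbers shown in this assay, compound 3 stands highest; the nearest lies one step away, a number 15 percentage points higher from compound 2 to compound 3 (beyond the scatter). The third value shown is a limit (the limit of < 5% in this assay, at which 1 of the 3 values shown sits). The steps from that limit are a number at least 17 percentage points higher from compound 1 to compound 2 (beyond the scatter) and a number at least 32 percentage points higher from compound 1 to compound 3 (beyond the scatter).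

Compound 4 `CNc1nccc(C(C)(C)C)n1` differs from compound 3 in one place: hydrogen in place of phenyl on an aromatic carbon. Every measured step changes the group on the nitrogen attached to the shared core; none touches the aromatic carbon that carries the phenyl. Among the measured compounds shown here, no measured step therefore bears on this change, and the direction must be judged from the change alone, which removes the largest group on the core of compound 3. A loss of some inhibition is expected, a number 22 percentage points lower from compound 3 to compound 4 (beyond the scatter), though with wide uncertainty. Compound 4 is estimated to give 15% in this assay, expected to fall between 0% and 38%, with a real chance that only a limit is reported.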

Compound 4, a percentage reported as inhibition, in the whole organism at one dose (the size of the read-out at that dose, not a potency): 34%
Compound 4: middle estimate off by 19 percentage points, on the low side, and the stated range covers the measured number.
By their numbers in this assay, from the lowest: compound 2; then compounds 4 and 3 (each within the scatter of the next). At a limit, below all of these: compound 1.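

Here the change falls for the first time on the aromatic carbon carrying the phenyl rather than on the nitrogen, and removing all of that ring, with hydrogen in its place, gives a number 3 percentage points lower from compound 3 to compound 4 (within the scatter). In this assay, the phenyl can therefore go from the methylamino compound without a loss that can be told from the scatter, whereas changing the group on the nitrogen gave a number 15 percentage points higher from compound 2 to compound 3 (beyond the scatter). Nothing given here offers a cause for this result.

The compounds shown leave open how a methyl, a chlorine atom or a carboxylic acid on this aromatic carbon would read in this assay. They also leave open whether hydrogen in place of phenyl would give a similar result with an acetylamino or plain amino group on the shared core, or whether compound 3 and compound 4 would stay alike at other doses.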